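A few compounds are considered here, and "the series" means these few. Any claim that something is new, unique, unknown or untested is made for them only; others in the source may bear on it.

In a functional assay on PC-3 cells (Homo sapiens) for cytotoxicity, read by MTT assay, with a stated time of 72 h (a lower number here means a stronger inhibitor, a higher number a weaker inhibitor), compound 3 `COc1cccc(/C=C/C(=O)Nc2cc(C(=O)c3cc(OC)c(OC)c(OC)c3)cc(OC)c2OC)c1` gives 13300 nM, the highest of the three numbers shown, although compound 1 `C#CCOc1cccc(/C=C/C(=O)Nc2cc(C(=O)c3cc(OC)c(OC)c(OC)c3)ccc2OC)c1` gives 13100 nM, which lies within the scatter of that figure. Among the measured compounds shown here, compound 2 `COc1ccc(/C=C/C(=O)Nc2cc(C(=O)c3cc(OC)c(OC)c(OC)c3)cc(OC)c2OC)cc1` gives 6300 nM, and the step of a 2.1-fold higher number from compound 2 to compound 3 (0.32 log units; beyond the scatter) is the only one that separates two compounds beyond the scatter. Compound 4 `C#CCOc1cccc(/C=C/C(=O)Nc2cc(C(=O)c3cc(OC)c(OC)c(OC)c3)cc(OC)c2OC)c1` differs from compound 3 by ethynyl in place of hydrogen on a saturated chain carbon bound to an oxygen on an aromatic ring. For the measured compounds named here, no measured step follows this exact change; compound 1 already carries the 3-(propargyloxy)phenyl group on a different core, and its value set against that of compound 3 shows no separation beyond the scatter. The change from compound 3 to compound 4 is therefore expected to give a 1.0-fold lower number from compound 3 to compound 4 (0.01 log units; within the scatter), essentially no shift. Compound 4 is estimated at 13000 nM, within a range from 6000 nM to 28000 nM.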

Compound 4, half-maximal inhibitory concentration: 10100 nM
The estimate for compound 4 lay 1.3-fold (0.11 log units) above the measured number, within the range that was stated.
By their numbers in this assay, from the lowest: compounds 2, 4, 1 and 3 (each within the scatter of the next, the first and the last beyond it).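

In this assay, 3-(propargyloxy)phenyl in place of 3-methoxyphenyl on the shared core gives no separation beyond the scatter (a 1.3-fold lower number from compound 3 to compound 4 (0.12 log units; within the scatter)), so this position tolerates the added ethynyl. Unlike 3-methoxyphenyl, it also stays within the scatter of the 4-methoxyphenyl compound (a 1.6-fold higher number from compound 2 to compound 4 (0.20 log units; within the scatter)). Methoxy in place of hydrogen on an aromatic carbon likewise stays within the scatter (a 1.3-fold lower number from compound 1 to compound 4 (0.11 log units; within the scatter)), and nothing available explains these results. The compounds shown leave open whether a longer chain on this oxygen, or a terminal amine, would move the number beyond the scatter.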